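Removing the chloro group: what compound 4 may show

This account rests on a few compounds, and the source may have more. Where it says the series, first, only, none or still open, it means among the compounds named here.

Measured so far:
Compound 1 `Brc1ccc(NCc2nc3ccc(Br)cc3[nH]2)cc1` gives 20% in a functional assay on the whole organism (strain albino) for inhibition, with Rattus norvegicus as the target, read by paw edema, with a stated time of 60 min, at a dose of 100 mg/kg by the oral route; on this read-out lower numbers stand for less inhibition and higher numbers for more inhibition at the one dose given (going by the name of the read-out).
Compound 2 `COc1ccc(NCc2nc3ccccc3[nH]2)cc1` gives 26.6% in this assay.
Compound 3 `Clc1cccc(NCc2nc3ccccc3[nH]2)c1` gives 26.6% in this assay.

Of the three numbers recorded, compound 3 stands level with compound 2 at the digits shown, and together they are the highest of the three. Compound 1 lies lower by an amount that is still within the usual scatter, so the three compounds cannot be ranked on these numbers alone.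

Compound 4 `c1ccc(NCc2nc3ccccc3[nH]2)cc1` has not yet been measured. It differs from compound 3 in one place: hydrogen in place of chloro on an aromatic carbon. Within the data shown here, no pair of measured compounds differing in only one place is available, so the size of this step cannot be read from an earlier one. The three measured values cluster closely, and the change is small. The step from compound 3 to compound 4 in this assay is therefore expected to be small, a number 4.6 percentage points lower from compound 3 to compound 4 (within the scatter), likely within the scatter, with a slight lean downward. Compound 4 is expected to give about 22%, between 10% and 34%.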

Compound 4, a percentage reported as inhibition, in the whole organism at one dose (the size of the read-out at that dose, not a potency): 26.6%
The estimate for compound 4 lay 4.6 percentage points below the measured number; measured number inside the range.
By their numbers in this assay, from the lowest: compounds 1, 2, 3 and 4 (each within the scatter of the next).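

Hydrogen in place of chloro on an aromatic carbon, meta to a large group, gives no change at the digits printed from compound 3 to compound 4 (within the scatter) in this assay, and this is the first reading of a single change at this position. Hydrogen in place of methoxy on an aromatic carbon gives no change at the digits printed from compound 2 to compound 4 (within the scatter), so at this one dose neither chloro nor methoxy sets its compound apart from compound 4, which carries only hydrogen there. No available evidence explains why these numbers coincide.

On these data alone, whether a different group at this place, such as an amine, a carboxylic acid or a longer chain, would move the number remains open. As far as these compounds go, with a single oral dose and a read-out of effect size rather than potency, it also remains open whether compounds 2, 3 and 4 would stay level at other doses.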